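Benzamide thioether series: aryl to phenethyl on sulfur

This account rests on a few compounds, and the source may have more. Where it says the series, first, only, none or still open, it means among the compounds named here.

Measured compounds:
- compound 1, `Nc1ccccc1NC(=O)c1ccc(CSc2ccc(Br)cc2)cc1`, 6.17%
- compound 2, `Cc1cc(C)cc(SCc2ccc(C(=O)Nc3ccccc3N)cc2)c1`, 74.7%
- compound 3, `CCc1ccc(SCc2ccc(C(=O)Nc3ccccc3N)cc2)cc1`, 71.1%

In a functional assay on A-375 cells (Homo sapiens) for inhibition, read by CCK-8 assay, with a stated time of 72 h, tested at 8 uM (on this read-out higher numbers stand for more inhibition of growth at the one concentration tested and lower numbers for less inhibition of growth), compound 3 stands second of the three numbers. Its neighbour is compound 2, and the step of a number 3.6 percentage points lower from compound 2 to compound 3 (within the scatter), so the two cannot be told apart on this read-out. Compound 1 lies far below both: a number 68.5 percentage points higher from compound 1 to compound 2 (beyond the scatter) and a number 64.9 percentage points higher from compound 1 to compound 3 (beyond the scatter). Thus within the measured set the 4-bromophenyl of compound 1 is the only variant that loses nearly all growth inhibition, while the two alkyl-substituted aryl thioethers sit together near the top.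

Compound 4 is `Nc1ccccc1NC(=O)c1ccc(CSCCc2ccccc2)cc1`. It differs from compound 3 by phenethyl in place of 4-ethylphenyl on a sulfur. Among the measured compounds shown here, no measured step covers this change: every measured pair keeps an aryl on the sulfur and varies only its substituents, whereas here the aryl moves away from the sulfur behind a saturated chain. For the measured compounds named here, the only steps at hand show that the group on sulfur can swing the read-out widely (a number 64.9 percentage points higher from compound 1 to compound 3 (beyond the scatter)) or not at all (a number 3.6 percentage points lower from compound 2 to compound 3 (within the scatter)), so the expectation carries a wide range. For compound 4 a moderate downward step is expected, a number 19.1 percentage points lower from compound 3 to compound 4 (beyond the scatter), with a correspondingly broad interval. The estimate for compound 4 in this assay is 52%, between 18% and 78%.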

Compound 4, percent growth inhibition at one concentration: 69.9%
Compound 4: middle estimate off by 17.9 percentage points, on the low side; measured number inside the range.
By their numbers in this assay, from the lowest: compound 1; then compounds 4, 3 and 2 (each within the scatter of the next).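

In this assay the change to phenethyl gives a number 1.2 percentage points lower from compound 3 to compound 4 (within the scatter) and a number 4.8 percentage points lower from compound 2 to compound 4 (within the scatter) so phenethyl cannot be told apart from 4-ethylphenyl or 3,5-dimethylphenyl on this sulfur. Among the compounds shown here, this is the first sign that the position tolerates an aromatic ring held away from the sulfur by a saturated chain, which the earlier pairs, all with an aryl directly on sulfur, could not show. The same change gives a number 63.7 percentage points higher from compound 1 to compound 4 (beyond the scatter) leaving compound 1 as the only one of the four far from the rest, and no measurement on hand explains this difference.

As far as these compounds go, whether this tolerance extends to a benzyl group, a longer chain such as 3-phenylpropyl, or a chain ending in an amine or a carboxylic acid remains open, as does whether a bromo on the phenethyl ring would bring the same loss as in compound 1. The single-concentration read-out also leaves open whether compounds 2, 3 and 4 would still be indistinguishable across a full concentration series.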